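Thiophenylmethyl ether in place of the benzyl ether

The compounds below may be only part of what the source reports. "The series", "measured", "known", "first", "only" and "open" are said of these compounds alone.

Three amine-ended ethers on a shared core have been run so far. Compound 1 `CN(C)CCCCOc1c(OCc2ccccc2)cc(O)c2c(=O)cc(-c3ccccc3)oc12` gives 3210 nM in a functional assay on MCF7 cells (Homo sapiens) for cytotoxicity, read by MTT assay, with a stated time of 72 h; a lower number here means a stronger inhibitor, a higher number a weaker inhibitor. Compound 2 `CCN(CC)CCCCOc1c(OCc2ccccc2)cc(O)c2c(=O)cc(-c3ccccc3)oc12` gives 1920 nM in this assay, and compound 3 `CN1CCN(CCCCOc2c(OCc3ccccc3)cc(O)c3c(=O)cc(-c4ccccc4)oc23)CC1` gives 2930 nM. All three numbers sit together: the steps of a 1.7-fold lower number from compound 1 to compound 2 (0.22 log units; within the scatter), a 1.1-fold lower number from compound 1 to compound 3 (0.04 log units; within the scatter) and a 1.5-fold higher number from compound 2 to compound 3 (0.18 log units; within the scatter) are each within the scatter, so compound 3 cannot be separated from compound 1 or compound 2 on these numbers.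

Compound 4 `CN1CCN(CCCCOc2c(OCc3cccs3)cc(O)c3c(=O)cc(-c4ccccc4)oc23)CC1` keeps the 4-methylpiperazin-1-yl end of compound 3 and changes the other ether: thiophen-2-yl in place of phenyl on a saturated chain carbon bound to an oxygen on an aromatic ring. Going by the values given here, no measured step touches this part of the molecule; the three steps that exist all concern the amine end and none of them moved the number beyond the scatter. With nothing bearing directly on the change, no step beyond the scatter is expected in this assay, in either direction. The estimate for compound 4 is therefore 2900 nM, with a range from 1200 nM to 7000 nM, which corresponds to an expected step of a 1.0-fold lower number from compound 3 to compound 4 (0.00 log units; within the scatter).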

Compound 4, half-maximal inhibitory concentration: 3180 nM
Estimate against measurement, compound 4: 1.1-fold (0.04 log units) below; low and high end bracket the measured number.
By their numbers in this assay, from the lowest: compounds 2, 3, 4 and 1 (each within the scatter of the next).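

Going by these compounds alone, the benzyl ether, untouched by the earlier steps, now has one measured change: with the 4-methylpiperazin-1-yl end held fixed, the move from benzyloxy to (thiophen-2-yl)methoxy gives a 1.1-fold higher number from compound 3 to compound 4 (0.04 log units; within the scatter) in this assay on this read-out. At this position, then, a five-membered aromatic ring with 1 hetero atom can stand in place of a six-membered aromatic ring of carbon only without separating compound 4 from compound 3, so the series now shows no step beyond the scatter at either ether end. Nothing available bears on why the number stays in place.

Going by these compounds, whether the same change reads alike with the dimethylamino or diethylamino end remains open. Also open, on these data alone, is how a pyridin-3-ylmethyl ether or a plain methyl ether would read at this oxygen.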